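Replacing the 4-aminophenyl group in a limit-bound series

This account rests on a few compounds, and the source may have more. Where it says the series, first, only, none or still open, it means among the compounds named here.

Measured in a functional assay on KYSE-410 cells (Homo sapiens) for antiproliferative activity, read by MTT assay, with a stated time of 72 h; on this read-out lower numbers stand for stronger inhibition and higher numbers for weaker inhibition:
- compound 1 (`CC(=O)c1ccc(-c2ccc3c(C(=O)Nc4cccc(F)c4)cc(=O)[nH]c3c2)cc1`) gives > 20000 nM as a limit
- compound 2 (`Cc1ccc(-c2ccc3c(C(=O)Nc4cccc(F)c4)cc(=O)[nH]c3c2)cc1`) gives > 20000 nM as a limit
- compound 3 (`Nc1ccc(-c2ccc3c(C(=O)Nc4cccc(F)c4)cc(=O)[nH]c3c2)cc1`) gives > 20000 nM as a limit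

Compound 3 stands only at the limit > 20000 nM and has no number. In compound 4 (`O=C(Nc1cccc(F)c1)c1cc(=O)[nH]c2cc(C3=CCOCC3)ccc12`), a non-aromatic ring replaces the 4-aminophenyl group on the same aromatic carbon (a group of 6 heavy atoms (5 carbon, 1 oxygen; one six-membered non-aromatic ring with 1 hetero atom) in place of a group of 7 heavy atoms (6 carbon, 1 nitrogen; one six-membered aromatic ring of carbon only), on an aromatic carbon). The measured steps are a step that the two limits leave unreadable from compound 1 to compound 2, a step that the two limits leave unreadable from compound 1 to compound 3 and a step that the two limits leave unreadable from compound 2 to compound 3, so none gives a size to carry over. The evidence amounts to the limit of > 20000 nM in this assay, at which 3 of the 3 values shown sit, and no more. In this assay the estimated step is a number no higher from compound 3 to compound 4 (the limit leaves the size open) and no direction is expected. Compound 4 is expected at 20000 nM with a range from 7000 nM to 50000 nM and will probably be reported as a limit again.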

Compound 4, half-maximal inhibitory concentration: 12100 nM
For compound 4 the middle estimate is 1.7-fold (0.22 log units) above the measured one, and the stated range covers the measured number.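

For the compounds shown here, compound 4 gives the first number at this position in this assay, 12100 nM, with a non-aromatic ring in place of an aromatic one on the same carbon. Against the aromatic-ring compounds, the readings are an at least 1.6-fold lower number from compound 3 to compound 4 (0.21 log units; that floor lies within the scatter), an at least 1.6-fold lower number from compound 2 to compound 4 (0.21 log units; that floor lies within the scatter) and an at least 1.6-fold lower number from compound 1 to compound 4 (0.21 log units; that floor lies within the scatter), all floors rather than sizes. The steps among compounds 1, 2 and 3 cannot be read, and one number stands against the shared limit: the limit of > 20000 nM in this assay, at which 3 of the 4 values shown sit.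

Open, from the compounds shown here alone, is whether a piperidine, a morpholine or a cyclohexyl group on this carbon would give a step beyond the scatter. Also open, going by these compounds, is what the double bond of compound 4 contributes.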